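This account rests on a few compounds, and the source may have more. Where it says the series, first, only, none or still open, it means among the compounds named here.

Compound 1 `CC(=O)OCCOCn1cc(C#N)c2c(N)ncnc21`, compound 2 `N#Cc1cn(COCCO)c2ncnc(N)c12` and compound 3 `NC(=NO)c1cn(COCCO)c2ncnc(N)c12` share one core and differ only at the side chain or at the group on the five-membered ring. In an ADME assay on BSC-1 cells (Cercopithecidae) for cytotoxicity (on this read-out lower numbers stand for stronger inhibition and higher numbers for weaker inhibition), compound 1 gives a limit of the assay, > 100000 nM. Compound 2 likewise gives only a limit in this assay, > 320000 nM. Compound 3 too gives a limit in this assay, > 100000 nM. The step that the two limits leave unreadable from compound 1 to compound 2 and the step that the two limits leave unreadable from compound 2 to compound 3 therefore cannot be read, since each sits between two limits; the three values sit at the limit of > 100000 nM in this assay, at which 2 of the 3 values shown sit, and (the limit of > 320000 nM in this assay, at which 1 of the 3 values shown sits). Compound 3 thus stands at a limit, with the other two values shown also being limits, so no ordering among the three can be drawn.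

Compound 4 `NNC(=O)c1cn(COCCO)c2ncnc(N)c12` differs from compound 3 by a group of 4 heavy atoms (1 carbon, 2 nitrogen, 1 oxygen; no ring) in place of a group of 4 heavy atoms (1 carbon, 2 nitrogen, 1 oxygen; no ring), on an aromatic carbon. Within the data shown here, the step that bears on the same place, from compound 2 to compound 3, left no readable size, and no measured step gives any direction for a change at this position. The expectation in this assay is therefore no step beyond the scatter, a step that the limit leaves unreadable from compound 3 to compound 4, and most likely another limit. Compound 4 is estimated at 150000 nM, within a range from 50000 nM to 400000 nM.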

Compound 4, half-maximal inhibitory concentration: > 100000 nM
Compound 4 was reported as a limit; the forecaster's own chance of this, stated with the estimate: 85%; the middle value does not contradict the limit.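

Compound 4 also gives only a limit in this assay, > 100000 nM. Neither the step from compound 3 to compound 4 nor the step from compound 2 to compound 4 can be read, since each joins two limits. The compounds shown leave open how compound 2, compound 3 and compound 4 rank in this assay, and whether any of them would give a measurable value.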